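The source may report more compounds than this note shows. Statements on the series, on what has been measured and on what is new or still open speak of the compounds shown alone.

Three compounds sharing one core have been examined in a functional assay on CHO cells for positive allosteric modulation of muscarinic acetylcholine receptor M5 (Homo sapiens), read by FLIPR and calcium flux, with a stated time of 1 h; on this read-out lower numbers stand for an effect already at smaller amounts and higher numbers for an effect only at larger amounts of compound. Compound 1 `O=C1C(=O)N(Cc2ccc(-c3cccnc3)cc2)c2ccc(OC(F)(F)F)cc21` gives 1600 nM. Compound 2 `O=C1C(=O)N(Cc2ccc(Cl)nc2)c2ccc(OC(F)(F)F)cc21` gives 2400 nM. Compound 3 `COc1cccc(Oc2ccc(CN3C(=O)C(=O)c4cc(OC(F)(F)F)ccc43)cc2)n1` gives 2200 nM. On these numbers compound 2 stands highest of the three, but its nearest neighbour is compound 3, a gap within the scatter, and even the gap to compound 1 stays within the scatter, so no order among the three can be claimed.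

Within the data shown here, the only single-point step among the measured compounds is a 1.4-fold higher number from compound 1 to compound 3 (0.14 log units; within the scatter), a change of the group on the outer aromatic ring that left the read-out essentially untouched.

Compound 4 `O=C1C(=O)N(Cc2ccc(-c3ccncc3)nc2)c2ccc(OC(F)(F)F)cc21` arises from compound 2 by pyridin-4-yl in place of chloro on an aromatic carbon. Among the measured compounds shown here, no measured step covers exactly this exchange of a halogen for an aromatic ring. What can be said is that compound 1, which carries a pyridin-3-yl group, and compound 2, which carries chloro, show values that lie within the scatter of one another, and that the step from compound 1 to compound 3 showed the outer group to be tolerant of substantial change. Compound 4 is therefore expected to give 1600 nM, between 500 nM and 5000 nM, a step of a 1.5-fold lower number from compound 2 to compound 4 (0.18 log units; within the scatter) that is expected not to exceed the scatter.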

Compound 4, half-maximal effective concentration: 4400 nM
Compound 4: the middle estimate sits 2.8-fold (0.44 log units) below what was measured; the range from low to high includes it.
By their numbers in this assay, from the lowest: compounds 1, 3, 2 and 4 (each within the scatter of the next, the first and the last beyond it).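

Among these compounds, the exchange of chloro for pyridin-4-yl, on an aromatic carbon next to the ring nitrogen and para to a large group, gives a 1.8-fold higher number from compound 2 to compound 4 (0.26 log units; within the scatter) in this assay and is the only measured step at this place. It shows that the single chlorine atom can be replaced by a six-membered aromatic ring of 6 heavy atoms, carrying 1 hydrogen-bond acceptor, with a step that stays within the scatter, so the earlier tolerance seen on the outer ring of compound 1 and compound 3 now has a counterpart at this second place. Nothing available explains why this exchange is tolerated, and no reason can be given for it.

The compounds shown leave open whether smaller or differently built groups at this place, such as an amine, a carboxylic acid or a longer chain, would also stay within the scatter or would reach beyond it. They also leave open whether pyridin-3-yl at this same place would read like pyridin-4-yl, and compound 4 and compound 1 differ in more than one place, so the gap between them cannot be tied to any single change.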